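The source may hold more compounds than are shown below. What is called first, only, known or untested is meant among the compounds shown, and "the series" means these compounds.

Measured in a functional assay on Raji cells (Homo sapiens) for cytotoxicity, with a stated time of 72 h; on this read-out lower numbers stand for an effect already at smaller amounts and higher numbers for an effect only at larger amounts of compound:
- compound 1 `C=C[C@@](C)(/C=C/c1ccc(O)cc1)CCCO`: > 26000 nM
- compound 2 `C=C[C@@](C)(/C=C/c1ccc(O)cc1)CC/C=C(\C)C=O`: > 26000 nM
- compound 3 `C=C[C@@](C)(/C=C/c1ccc(O)c(/C=C/C(=O)OCc2ccccc2)c1)CCC=C(C)C`: > 26000 nM

Each of these three entries is a limit of the assay, not a number.

Compound 3 therefore has no exact position on this scale. Its entry of > 26000 nM is a limit, and it cannot be ranked against compound 1 or compound 2.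

The next structure is compound 4 `C=C[C@@](C)(/C=C/c1ccc(O)c(/C=C/C=C/c2ccccc2)c1)CCC=C(C)C`. The change is 2-phenylethenyl in place of benzyloxycarbonyl on a double-bonded chain carbon bound to a double-bonded chain carbon. In words, 2-phenylethenyl replaces benzyloxycarbonyl on a double-bonded chain carbon bound to a double-bonded chain carbon. Both groups carry one six-membered aromatic ring of carbon only.

Within the data shown here, only one measured step is available for comparison, a step that the two limits leave unreadable from compound 1 to compound 2. It involves different groups and has no readable size, so it gives no size to carry over. No direction can be drawn from the data either, due to the limit of > 26000 nM in this assay, at which 3 of the 3 values shown sit. In this assay, no clear step is therefore expected, and compound 4 may again return only a limit. The expected change is a number no higher from compound 3 to compound 4 (the limit leaves the size open). For compound 4, the estimated value is 26000 nM, with an expected range from 9000 nM to 60000 nM.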

Compound 4, half-maximal effective concentration: > 26000 nM
Compound 4 ended at the assay's limit; the forecaster's own chance of this, stated with the estimate: 70%; the middle value lies on the limit itself.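

No step can be read from compound 3 to compound 4, where 2-phenylethenyl replaces benzyloxycarbonyl, because both entries in this assay are limits rather than numbers: the limit of > 26000 nM in this assay, at which 4 of the 4 values shown sit.

The compounds shown leave open where any of them truly lies on this scale, and which structural changes would shift the value at all.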